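A few compounds are considered here, and "the series" means these few. Any claim that something is new, unique, unknown or untested is made for them only; others in the source may bear on it.

Working notes on the series. The shared core of compound 1 `CCCC(=O)C1=C(C)NC(=O)NC1c1ccco1` carries a furan-2-yl on a saturated ring carbon; in an assay on membranes from HeLa cells for displacement of a labelled ligand from adenosine receptor A3 (Homo sapiens), read by scintillation counting, with a stated time of 180 min, tested at 1 uM (a lower number here means less inhibition, a higher number more inhibition at the concentration tested (going by the name of the read-out)), compound 1 gives 1%. Compound 2 `CCCC(=O)C1=C(C)NC(=O)NC1c1ccoc1` gives 2% in this assay, and compound 3 `CCCC(=O)C1=C(C)NC(=O)NC1c1ccsc1` gives 1% in this assay. The three measured steps are a number 1 percentage points higher from compound 1 to compound 2 (within the scatter), no change at the digits printed from compound 1 to compound 3 (within the scatter) and a number 1 percentage points lower from compound 2 to compound 3 (within the scatter), each within the scatter. Compound 1 thus stands level with compound 3 at the digits printed, and the value of compound 2 lies within the scatter of both; none of the three can be told apart from the others in this assay.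

Compound 4 `CCN(CC)C(=O)C1=C(C)NC(=O)NC1c1ccco1` differs from compound 1 by diethylamino in place of propyl on a carbonyl carbon. Among the compounds with values here, no measured step touches the carbonyl carbon: every step so far swaps the aryl group on the saturated ring carbon and leaves the carbonyl substituent untouched, so nothing measured bears directly on this change. What the measured compounds do show is that the core as a whole sits at the bottom of the read-out in this assay regardless of the aryl group. The expectation for compound 4 in this assay is therefore a step of a number 3 percentage points higher from compound 1 to compound 4 (within the scatter), that is, none beyond the scatter. Compound 4 is estimated at 4% in this assay, with a range from -6% to 18%.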

Compound 4, a percentage reported as inhibition, at one concentration (the size of the read-out at that concentration, not a potency): 19%
Compound 4: middle estimate off by 15 percentage points, on the low side; measured number above the stated range.
By their numbers in this assay, from the lowest: compounds 1, 3 and 2 (each within the scatter of the next); then compound 4.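

In this assay, within the data shown here, the carbonyl carbon is the first place where a single change gives a step beyond the scatter: diethylamino in place of propyl gives a number 18 percentage points higher from compound 1 to compound 4 (beyond the scatter) and the step is modest in size. The earlier steps shown here all swapped the aryl group on the saturated ring carbon and stayed within the scatter, so the low numbers of compound 1, compound 2 and compound 3 now read as belonging to the propyl compounds and not to every compound with the shared core. Among these compounds, nothing measured so far accounts for this step.

As far as these compounds go, whether the step follows from the nitrogen that enters or from the larger group stays open, as this one pair changes both at once; a butyl chain, a dimethylamino group or a piperidin-1-yl group on the same carbonyl carbon would begin to separate the two. From the compounds shown here alone, it is also open whether diethylamino gives a similar step alongside furan-3-yl or thiophen-3-yl on the saturated ring carbon.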